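Efficacy in prostaglandin D2 receptor 2 antagonist series

The source may hold more compounds than are shown below. What is called first, only, known or untested is meant among the compounds shown, and "the series" means these compounds.

Measured compounds:
compound 1 `O=C(O)Cc1sc(C(c2ccc(F)cc2)c2ccc(F)cc2)nc1-c1ccc(Cl)cc1`: 80%
compound 2 `Nc1cc(-c2nc(C(c3ccc(F)cc3)c3ccc(F)cc3)sc2CC(=O)O)cc(F)n1`: 30%

In an in vitro functional assay on HEK285-7 cells for antagonist activity at prostaglandin D2 receptor 2 (Homo sapiens), read by BRET and beta-arrestin recruitment (on this read-out higher numbers stand for larger maximal responses and lower numbers for smaller maximal responses), compound 2 gives the lowest of the two numbers; its nearest neighbour is compound 1, the step being a number 50 percentage points lower from compound 1 to compound 2 (beyond the scatter). Compound 3 `O=C(O)Cc1sc(C(c2ccc(F)cc2)c2ccc(F)cc2)nc1-c1ccco1` differs from compound 2 in one place: furan-2-yl in place of 2-amino-6-fluoropyridin-4-yl on an aromatic carbon. Among the measured compounds shown here, the only step that bears on this is the one from compound 1 to compound 2, which removed the 4-chlorophenyl and was large; compound 3 now removes the 2-amino-6-fluoropyridin-4-yl again. A partial return upward is therefore expected, a number 35 percentage points higher from compound 2 to compound 3 (beyond the scatter). Compound 3 is estimated at 65%, with a range from 40% to 90%.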

Compound 3, largest response reached (reported as efficacy), in percent of the reference or control that the assay uses: 80%
For compound 3 the middle estimate is 15 percentage points below the measured one; the measured number falls inside the stated range.
By their numbers in this assay, from the lowest: compound 2; then compounds 1 and 3 (each within the scatter of the next).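

Notes on the position next to the ring nitrogen: in this assay, furan-2-yl undoes the loss seen with 2-amino-6-fluoropyridin-4-yl, a number 50 percentage points higher from compound 2 to compound 3 (beyond the scatter). The same position accepts the five-membered furan-2-yl as readily as 4-chlorophenyl, no change at the digits printed from compound 1 to compound 3 (within the scatter), so the six-membered aromatic ring is not required for the higher number. No measured evidence bears on the reason for this result.

Still open, on these data alone, is whether the low number of compound 2 follows its amino group, its fluorine or its ring nitrogen. A plain pyridin-4-yl or a thiophen-2-yl at this position remains an unknown.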